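Cytotoxicity of a shared core with a varied amide substituent

The compounds below may be only part of what the source reports. "The series", "measured", "known", "first", "only" and "open" are said of these compounds alone.

Compound 1 `CC(C)n1ncc2c(C(=O)Nc3ccc(F)cc3)cc(-c3cccs3)nc21`: > 200000 nM
Compound 2 `CC(C)n1ncc2c(C(=O)Nc3ccc(F)cc3)cc(-c3ccco3)nc21`: > 200000 nM
Compound 3 `CC(C)n1ncc2c(C(=O)Nc3ccccc3F)cc(-c3cncs3)nc21`: 100000 nM

In an ADME assay on LLC-MK2 cells (Macaca mulatta) for cytotoxicity, read by spectrophotometry and crystal violet staining, with a stated time of 4 days (a higher number here means that more compound is tolerated, a lower number that less compound is tolerated), compound 1 gives > 200000 nM, which is a limit of the assay and not a number. For compound 2 the value of > 200000 nM is also a limit. Compound 3 gives 100000 nM. The step that the two limits leave unreadable from compound 1 to compound 2 therefore cannot be sized, since both values sit at the limit of > 200000 nM in this assay, at which 2 of the 3 values shown sit. Compound 1 thus stands at the tolerated end of what the assay can report, together with compound 2, while compound 3 has a readable number.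

Compound 4 `CC(C)n1ncc2c(C(=O)Nc3cccc(S(N)(=O)=O)c3)cc(-c3cccs3)nc21` differs from compound 1 in one place: 3-sulfamoylphenyl in place of 4-fluorophenyl on an amide-type nitrogen. For the measured compounds named here, no measured step changes the group on the amide-type nitrogen, so nothing among the measured pairs bears directly on this change. With two of three values at the limit and the third a readable number of similar order, compound 4 is expected to remain well tolerated, with a step of an at least 1.1-fold lower number from compound 1 to compound 4 (0.04 log units; that floor lies within the scatter) that is most likely not beyond the scatter. The estimate for compound 4 is 180000 nM, with a range from 70000 nM to 400000 nM, and a fair chance that only a limit is reported again.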

Compound 4, half-maximal cytotoxic concentration: 25000 nM
For compound 4 the middle estimate is 7.2-fold (0.86 log units) above the measured one; measured number outside the range, below it.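

In this assay, putting 3-sulfamoylphenyl in place of 4-fluorophenyl on the amide-type nitrogen gives an at least 8.0-fold lower number from compound 1 to compound 4 (0.90 log units; beyond the scatter), so the group at this position can matter for how much compound the cells tolerate. The true size of this step may be larger, because compound 1 has a limit and not a number: the limit of > 200000 nM in this assay, at which 2 of the 4 values shown sit. The 4-fluorophenyl group leaves as the 3-sulfamoylphenyl group enters, so this single comparison cannot show whether losing the fluorine, gaining the sulfamoyl group or the different place of the substituent on the ring accounts for the lower number.

The compounds shown leave open which of these matters, and a plain phenyl group on the same nitrogen, or a methylsulfonyl group or a carboxylic acid in place of the sulfamoyl group, would help to separate these possibilities. They also leave open whether 3-sulfamoylphenyl would lower the number to a similar degree in a compound with furan-2-yl in place of thiophen-2-yl, as in compound 2.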